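This account rests on a few compounds, and the source may have more. Where it says the series, first, only, none or still open, it means among the compounds named here.

Of the compounds shown here, three built on one shared core have so far been tested in an assay on microsomes from brain for inhibition of Fatty-acid amide hydrolase 1 (Rattus norvegicus), read by fluorescence and HPLC, with a stated time of 60 min; a higher number here means a weaker inhibitor, a lower number a stronger inhibitor. Compound 1 `CCCCCCCCc1ccc(OCC(=O)Cn2nnc(C)n2)cc1` gives 27 nM, compound 2 `CCCCCCCCc1ccc(OCC(=O)Cn2nnc(SC)n2)cc1` gives 31 nM, and compound 3 `CCCCCCCCc1ccc(OCC(=O)Cn2nnc(-c3ccc(Cl)cc3)n2)cc1` gives 35 nM. Among these three numbers compound 2 stands second highest; its nearest neighbour is reached by the step of a 1.1-fold higher number from compound 2 to compound 3 (0.05 log units; within the scatter), and the step of a 1.1-fold higher number from compound 1 to compound 2 (0.06 log units; within the scatter) is also within the scatter, so the three compounds cannot be told apart on these data.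

Compound 4 `CCCCCCCCc1ccc(OCC(=O)Cn2nnc(-c3ccccc3Cl)n2)cc1` is the next compound of the series. It differs from compound 2 in one place: 2-chlorophenyl in place of methylsulfanyl on an aromatic carbon. Every measured step in this series changes the group at exactly this aromatic carbon, between two ring nitrogen atoms, and none of them moved the number beyond the scatter: a 1.1-fold higher number from compound 1 to compound 2 (0.06 log units; within the scatter), a 1.3-fold higher number from compound 1 to compound 3 (0.11 log units; within the scatter) and a 1.1-fold higher number from compound 2 to compound 3 (0.05 log units; within the scatter). The closest guide is the step from methylsulfanyl to 4-chlorophenyl, a 1.1-fold higher number from compound 2 to compound 3 (0.05 log units; within the scatter), which is small. Compound 4 is therefore expected to show no step beyond the scatter in this assay, that is a 1.1-fold higher number from compound 2 to compound 4 (0.05 log units; within the scatter). Compound 4 is estimated to give about 35 nM, with a plausible range from 15 nM to 85 nM.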

Compound 4, half-maximal inhibitory concentration: 32 nM
Estimate against measurement, compound 4: 1.1-fold (0.04 log units) above, and the stated range covers the measured number.
By their numbers in this assay, from the lowest: compounds 1, 2, 4 and 3 (each within the scatter of the next).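

Among the compounds shown here, changing 4-chlorophenyl to 2-chlorophenyl is the first comparison between two groups with the same atoms, and in this assay it stays within the scatter (a 1.1-fold lower number from compound 3 to compound 4 (0.04 log units; within the scatter)). The same group also gives no step beyond the scatter when it replaces the smaller methylsulfanyl (a 1.0-fold higher number from compound 2 to compound 4 (0.01 log units; within the scatter)) or methyl (a 1.2-fold higher number from compound 1 to compound 4 (0.07 log units; within the scatter)), so four different groups on this aromatic carbon, between two ring nitrogen atoms, cannot be told apart by their numbers. No measurement shown here explains this flat result.

Going by these compounds, all four groups are uncharged and have no hydrogen-bond donor, so it remains open whether an amine or a carboxylic acid on this carbon would produce a step beyond the scatter. Because the rest of the shared core stays the same in all four compounds, it is also unknown whether this flat result would hold with a shorter chain in place of the long carbon chain.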